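Nitro in Place of Hydrogen and Vero Cell Toxicity

The source may report more compounds than this note shows. Statements on the series, on what has been measured and on what is new or still open speak of the compounds shown alone.

Measured in an ADME assay on Vero cells (Chlorocebus sabaeus) for cytotoxicity, read by crystal violet staining; on this read-out higher numbers stand for lower toxicity in this test and lower numbers for higher toxicity in this test:

Compound 1 `CN(C)CCCNc1ccc(/N=N/c2ccccc2)cc1` gives 30000 nM.
Compound 2 `O=[N+]([O-])c1cccc(/N=N/N2CCCC2)c1` gives 80000 nM.
Compound 3 `c1ccc(/N=N/N2CCCC2)cc1` reaches only a limit of the assay, > 100000 nM.

Compound 1 and compound 2 are built on different cores, and how those cores differ is not broken down here. Of the two numbers, compound 1 shows the lower one, and the gap to compound 2 is beyond the usual scatter of repeated measurements.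

Compound 3 and compound 2 share a core and differ in one place: nitro in place of hydrogen on an aromatic carbon. The step of an at least 1.2-fold lower number from compound 3 to compound 2 (0.09 log units; that floor lies within the scatter) cannot be sized more closely than that, since (the limit of > 100000 nM in this assay, at which 1 of the 3 values shown sits).

Compound 4 `CN(C)CCCNc1ccc(/N=N/c2ccc([N+](=O)[O-])cc2)cc1` is not yet measured. It stands to compound 1 as compound 2 stands to compound 3: nitro in place of hydrogen on an aromatic carbon. The surroundings are not identical, since in compound 4 the nitro group sits para to a large group, whereas in compound 2 it sits meta to a group of 7 heavy atoms; so this is the same kind of change, not the same change.

The expectation for compound 4 therefore rests on compound 1 with 30000 nM and on the step of an at least 1.2-fold lower number from compound 3 to compound 2 (0.09 log units; that floor lies within the scatter) seen once before. On that footing the estimated step is a 1.2-fold lower number from compound 1 to compound 4 (0.08 log units; within the scatter). For compound 4 in this assay the estimated value is 25000 nM, expected to lie between 8000 nM and 80000 nM.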

Compound 4, half-maximal cytotoxic concentration: 60000 nM
Beside the measured number, compound 4's estimate is 2.4-fold (0.38 log units) below it; measured number inside the range.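

In this assay, nitro in place of hydrogen on an aromatic carbon of the core of compound 1 gives a 2.0-fold higher number from compound 1 to compound 4 (0.30 log units; within the scatter), a step no larger than the differences seen between repeated measurements of this kind. For the compounds shown here, this does not show that the change carries over unchanged from one core to another, nor that it behaves differently on the two cores, each of which offers only a single pair: the same change on two cores in this assay, an at least 1.2-fold lower number (0.09 log units; that floor lies within the scatter) from compound 3 to compound 2 and a 2.0-fold higher number (0.30 log units; within the scatter) from compound 1 to compound 4; the limit leaves it open whether they differ. For compound 3, > 100000 nM is a limit of the assay and not a number.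

Among the compounds shown, the changed aromatic carbon carries only hydrogen or nitro, so it remains open whether an amine, a carboxylic acid or a methoxy group in that place would give a step beyond the scatter on either core. Also open, from the compounds shown here alone, is whether a longer chain in place of the chain on compound 1 would alter the number in this assay, and whether nitro would give a similar step on that core elsewhere on the ring.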